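Methyl on the fused ring: a positional isomer

The source may hold more compounds than are shown below. What is called first, only, known or untested is meant among the compounds shown, and "the series" means these compounds.

Compound 1 `O=C(Nc1cccc(-c2nc3ccccc3[nH]2)c1)c1cccs1` is one of two compounds examined in an ADME assay on NIH3T3 cells (Mus musculus) for cytotoxicity, read by resazurin assay, with a stated time of 48 h; on this read-out higher numbers stand for weaker inhibition and lower numbers for stronger inhibition; there compound 1 gives 15000 nM. It stands as the lower of the two numbers, with compound 2 `Cc1ccc2[nH]c(-c3cccc(NC(=O)c4cccs4)c3)nc2c1` nearest: in this assay compound 2 gives 16700 nM, a step of a 1.1-fold higher number from compound 1 to compound 2 (0.05 log units; within the scatter). Compound 3 `Cc1cccc2[nH]c(-c3cccc(NC(=O)c4cccs4)c3)nc12` has not yet been measured. It differs from compound 1 by methyl in place of hydrogen on an aromatic carbon, the new group sitting on an aromatic carbon of a six-membered aromatic ring of carbon only, part of a fused system of two rings, ortho to a fused ring and meta to a fused ring. Among the compounds with values here, the only measured step that bears on this change is the one from compound 1 to compound 2, where a methyl on another aromatic carbon of the same fused ring moved the number by a 1.1-fold higher number from compound 1 to compound 2 (0.05 log units; within the scatter), within the scatter. On that basis no step beyond the scatter is expected from compound 1 to compound 3, an expected 1.1-fold higher number from compound 1 to compound 3 (0.03 log units; within the scatter). For compound 3 the estimate in this assay is 16000 nM, expected to lie between 8000 nM and 32000 nM.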

Compound 3, half-maximal inhibitory concentration: > 300000 nM
Compound 3 gave a limit, no number (the forecaster's own chance of this, stated with the estimate: 5%); middle value at least 18-fold (1.27 log units) away from the limit.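

Methyl in place of hydrogen on this aromatic carbon, ortho to a fused ring and meta to a fused ring, gives an at least 20-fold higher number from compound 1 to compound 3 (1.30 log units; beyond the scatter), while the same replacement on another aromatic carbon of the same fused ring gave a 1.1-fold higher number from compound 1 to compound 2 (0.05 log units; within the scatter). The earlier pair alone suggested that this fused ring accepts a methyl without any readable change in this assay, but the new step shows that this holds only for the carbon carrying the methyl in compound 2, and that on this read-out the carbon in compound 3 goes with much weaker inhibition. The figure for compound 3 is a limit of the assay and not a number, so the step gives only a minimum size: the limit of > 300000 nM in this assay, at which 1 of the 3 values shown sits.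

The compounds shown leave open whether this large step belongs to methyl itself or would also appear with another group on the same carbon, such as a chlorine atom, a methoxy group or an amine. They also do not show how far the true value of compound 3 lies past its limit, nor what underlies the step.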